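The source may hold more compounds than are shown below. What is called first, only, known or untested is meant among the compounds shown, and "the series" means these compounds.

Working notes on the series.

Compound 1 `COc1ccc(NC(=O)CNc2c([N+](=O)[O-])cc(C(=O)NCCO)cc2[N+](=O)[O-])cc1` is the parent, with a hydrogen on the saturated chain carbon bound to a carbonyl carbon and a nitrogen on an aromatic ring. In an ADME assay for pharmacokinetics (on this read-out higher numbers stand for a longer-lived compound and lower numbers for a shorter-lived compound), compound 1 gives only a limit of the assay, < 0.0167 h, and no number.

Compound 2 `COc1ccc(NC(=O)C(C)Nc2c([N+](=O)[O-])cc(C(=O)NCCO)cc2[N+](=O)[O-])cc1` carries a methyl in place of that hydrogen. In this assay compound 2 likewise gives only a limit of the assay, < 0.0167 h. Compound 2 therefore stands at the floor of what the assay reports, and every value shown in the series sits there: the limit of < 0.0167 h in this assay, at which 2 of the 2 values shown sit. The step that the two limits leave unreadable from compound 1 to compound 2 cannot be read, since both ends are limits.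

Compound 3 `COc1ccc(NC(=O)C(C)(C)Nc2c([N+](=O)[O-])cc(C(=O)NCCO)cc2[N+](=O)[O-])cc1` introduces (methyl in place of hydrogen on a saturated chain carbon bound to a carbonyl carbon, a nitrogen on an aromatic ring and a saturated chain carbon). Among the compounds with values here, the only measured step that bears on this change, from compound 1 to compound 2, is of the same kind, and its size is not readable, so no direction and no size can be taken from it. The expectation is that compound 3 stays close to where compound 2 stands, with an expected step of an at least 1.1-fold higher number from compound 2 to compound 3 (0.07 log units; that floor lies within the scatter) in this assay. Compound 3 is estimated at 0.02 h, in the range 0.008 h to 0.08 h, most likely again reported only as a limit.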

Compound 3, half-life: < 0.0167 h
Compound 3: only a limit was reported (the forecaster's own chance of this, stated with the estimate: 65%); middle value at least 1.1-fold (0.07 log units) from the limit.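

In this assay compound 3 gives only a limit of the assay, < 0.0167 h. Compound 2 also stands at a limit, so the step between compound 2 and compound 3 cannot be read. The compounds shown leave open what the actual values are and whether methyl in place of hydrogen changes them at all: the limit of < 0.0167 h in this assay, at which 3 of the 3 values shown sit.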